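A piperidin-1-yl swap at the assay limit

The source may report more compounds than this note shows. Statements on the series, on what has been measured and on what is new or still open speak of the compounds shown alone.

compound 1 `Cn1cc(C2=C(c3nn(CCn4ccnc4)c4ncccc34)C(=O)N(c3ccccc3)C2=O)c2ccccc21` | > 100000 nM (a limit)
compound 2 `Cn1cc(C2=C(c3nn(CCCn4cccc4)c4ncccc34)C(=O)NC2=O)c2ccccc21` | > 100000 nM (a limit)

In a functional assay on KB cells (Homo sapiens) for antiproliferative activity, read by MTT assay, with a stated time of 48 h (a higher number here means a weaker inhibitor, a lower number a stronger inhibitor), compound 2 reads > 100000 nM, which is a limit of the assay and not a number. Going by the values given here, the same holds across the small set, with the limit of > 100000 nM in this assay, at which 2 of the 2 values shown sit, so no measured step exists to serve as a guide.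

Compound 3 `Cn1cc(C2=C(c3nn(CCCN4CCCCC4)c4ncccc34)C(=O)NC2=O)c2ccccc21` differs from compound 2 in one place, (piperidin-1-yl in place of 1H-pyrrol-1-yl on a saturated chain carbon, three bonds along the chain from an aromatic nitrogen), with piperidin-1-yl in place of 1H-pyrrol-1-yl on a saturated chain carbon, three bonds along the chain from an aromatic nitrogen.

The data fix no size for this change in this assay, and it may leave the reading at the limit. Any real number would have to fall on the stronger side. The expected step is an at least 2.0-fold lower number from compound 2 to compound 3 (0.30 log units; that floor lies within the scatter), a modest one. For compound 3 the estimated value is 50000 nM, with an expected range from 8000 nM to 100000 nM.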

Compound 3, half-maximal inhibitory concentration: 98000 nM
The estimate for compound 3 lay 2.0-fold (0.29 log units) below the measured number, and the stated range covers the measured number.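

In this assay, going by these compounds alone, compound 3 gives 98000 nM, the first reading in this small set that is a real number and not a limit of the assay. The step is an at least 1.0-fold lower number from compound 2 to compound 3 (0.00 log units; that floor lies within the scatter), so piperidin-1-yl in place of 1H-pyrrol-1-yl, on a saturated chain carbon, three bonds along the chain from an aromatic nitrogen, cannot be told apart from no change at all. Compound 3 nevertheless gives this position a measured anchor, although the set as a whole stays at the weak end of the assay: the limit of > 100000 nM in this assay, at which 2 of the 3 values shown sit.

From the compounds shown here alone, whether any group at this place can bring a clearly lower number remains open, and a morpholin-4-yl ring, a dimethylamino group or a longer chain could now be judged against compound 3. The compounds shown also give no reason for the weak readings.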